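The source may report more compounds than this note shows. Statements on the series, on what has been measured and on what is new or still open speak of the compounds shown alone.

Compound 1 `COc1cc2nc(Nc3ccc(C#N)cc3)nc(Nc3c(Cl)cc(/C=C/C#N)cc3Cl)c2cc1OC` — 9920 nM
Compound 2 `COc1cc2nc(SCC(=O)Nc3ccc(C)cc3)nc(Nc3c(Cl)cc(/C=C/C#N)cc3Cl)c2cc1OC` — 2540 nM
Compound 3 `COc1cc2nc([S+]([O-])CC(=O)Nc3cccc(Cl)c3)nc(Nc3c(Cl)cc(/C=C/C#N)cc3Cl)c2cc1OC` — 68900 nM

In an ADME assay on MT4 cells (Homo sapiens) for cytotoxicity, read by MTT assay, with a stated time of 5 days (a lower number here means that less compound is tolerated, a higher number that more compound is tolerated), compound 3 gives the highest of the three numbers; its gap to compound 1 and its wider gap to compound 2 both lie beyond the scatter. Compound 4 `COc1cc2nc([S+]([O-])CC(=O)Nc3cc([N+](=O)[O-])ccc3F)nc(Nc3c(Cl)cc(/C=C/C#N)cc3Cl)c2cc1OC` differs from compound 3 only at the outer end of the side chain: 2-fluoro-5-nitrophenyl in place of 3-chlorophenyl on an amide-type nitrogen. Among the measured compounds shown here, the single measured step, a 3.9-fold lower number from compound 1 to compound 2 (0.59 log units; beyond the scatter), changes the group on the core, not the outer ring, so it does not bear directly on this change and was modest in size. With nothing measured at the outer ring, no step beyond the scatter is expected here, a 1.4-fold lower number from compound 3 to compound 4 (0.14 log units; within the scatter). For compound 4 the expected value in this assay is 50000 nM, within 20000 nM to 140000 nM.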

Compound 4, half-maximal cytotoxic concentration: > 194000 nM
Compound 4: a limit, no number; the forecaster's own chance of this, stated with the estimate: 25%; middle value at least 3.8-fold (0.58 log units) from the limit.
By their numbers in this assay, from the lowest: compound 2; then compound 1; then compound 3. At a limit, above all of these: compound 4.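

In this assay, the outer ring of the side chain turns out to count: 2-fluoro-5-nitrophenyl in place of 3-chlorophenyl gives an at least 2.8-fold higher number from compound 3 to compound 4 (0.44 log units; beyond the scatter) and so more compound is tolerated. Among the compounds shown here, the earlier step changed only the group on the core, so this is the first sign that the far end of the chain also moves this number. Compound 4 stands at a limit, not a number, so the full size of the step stays unknown: the limit of > 194000 nM in this assay, at which 1 of the 4 values shown sits.

The ring changes in more than one way, so the compounds shown do not tell whether the fluorine or the nitro group carries the step. A phenyl ring bearing only fluorine, or an amine in place of the nitro group, would help separate the two.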